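Aryl changes on the shared core: compound 3 to compound 4

The source may hold more compounds than are shown below. What is called first, only, known or untested is meant among the compounds shown, and "the series" means these compounds.

Measured in a functional assay on MCF7 cells (Homo sapiens) for antiproliferative activity, read by MTT assay, with a stated time of 72 h; a lower number here means a stronger inhibitor, a higher number a weaker inhibitor:
Compound 1 `COc1cc(-n2cnc3ccc(-c4ccccc4Cl)cc32)cc(OC)c1OC`: > 10000 nM (a limit of the assay, not a number)
Compound 2 `COc1cc(-n2cnc3ccc(-c4cccc(Cl)c4)cc32)cc(OC)c1OC`: 3120 nM
Compound 3 `COc1cc(-n2cnc3ccc(-c4cccc(F)c4)cc32)cc(OC)c1OC`: 2350 nM

In this assay compound 3 gives 2350 nM. Its nearest neighbour is compound 2, and a 1.3-fold lower number from compound 2 to compound 3 (0.12 log units; within the scatter) keeps the pair within the scatter. Going by the values given here, the only other reading is the limit of compound 1.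

Compound 4 `COc1cc(-n2cnc3ccc(-c4ccc(C)cc4)cc32)cc(OC)c1OC` follows from compound 3 by one change, 4-methylphenyl in place of 3-fluorophenyl on an aromatic carbon. Among the compounds with values here, three measured steps bear on it. Fluoro in place of chloro gave a 1.3-fold lower number from compound 2 to compound 3 (0.12 log units; within the scatter). Larger changes came with 3-chlorophenyl in place of 2-chlorophenyl, an at least 3.2-fold lower number from compound 1 to compound 2 (0.50 log units; beyond the scatter), and with 3-fluorophenyl in place of 2-chlorophenyl, an at least 4.2-fold lower number from compound 1 to compound 3 (0.62 log units; beyond the scatter). Within the data shown here, the aryl group can therefore matter, but no 4-methylphenyl compound has been measured, so the direction stays open. The estimated step is a 1.3-fold higher number from compound 3 to compound 4 (0.11 log units; within the scatter), expected to stay within the scatter. For compound 4 the expected value is 3000 nM, with an estimated range of 1000 nM to 9000 nM.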

Compound 4, half-maximal inhibitory concentration: 110 nM
Compound 4: middle estimate off by 27-fold (1.44 log units), on the high side; the measured number lies below the stated range.
By their numbers in this assay, from the lowest: compound 4; then compounds 3 and 2 (each within the scatter of the next). At a limit, above all of these: compound 1.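

In this assay, this aryl position gives far larger steps than the halogen exchanges alone suggested: a 21-fold lower number from compound 3 to compound 4 (1.33 log units; beyond the scatter) and a 28-fold lower number from compound 2 to compound 4 (1.45 log units; beyond the scatter). The groups leaving and entering match in heavy-atom count and in hydrogen-bond donors and acceptors, so those counts do not separate 4-methylphenyl from 3-fluorophenyl. The third step, an at least 90-fold lower number from compound 1 to compound 4 (1.95 log units; beyond the scatter), starts from compound 1, which stands at a limit of the assay and not at a number: the limit of > 10000 nM in this assay, at which 1 of the 4 values shown sits.

Still open, as far as these compounds go, is whether the gain follows the methyl group or its place on the phenyl ring, a question that 3-methylphenyl and 4-chlorophenyl would separate. Also open, from the compounds shown here alone, is how a longer chain such as 4-ethylphenyl, or an amine such as 4-aminophenyl, would read in this assay.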